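The compounds below may be only part of what the source reports. "The series", "measured", "known", "first", "only" and "open" are said of these compounds alone.

Compound 1 `COc1ccc(S(=O)(=O)Nc2cccc(N3C[C@@H](c4ccc(OC)c(OC5CCCC5)c4)CC3=O)c2)cc1` gives, as a limit, > 10000 nM in a functional assay on HEK293 cells (Homo sapiens) for cytotoxicity; on this read-out higher numbers stand for lower toxicity in this test and lower numbers for higher toxicity in this test.
Compound 2 `COc1ccc([C@H]2CC(=O)N(c3cccc(NS(=O)(=O)c4cccc(Cl)c4C)c3)C2)cc1OC1CCCC1` gives, as a limit, > 10000 nM in this assay.

Both numbers shown are limits of this assay rather than measured values, so compound 2 stands at the edge of what this assay can report, and its only measured neighbour, compound 1, stands at the same edge. For the measured compounds named here, the one step that joins them, a step that the two limits leave unreadable from compound 1 to compound 2, therefore cannot be read in size or direction; all that can be said is the limit of > 10000 nM in this assay, at which 2 of the 2 values shown sit.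

Compound 3 `COc1ccc([C@H]2CC(=O)N(c3cccc(NS(=O)(=O)c4c(Br)nn(C)c4Cl)c3)C2)cc1OC1CCCC1` differs from compound 2 in a single place: 3-bromo-5-chloro-1-methyl-1H-pyrazol-4-yl in place of 3-chloro-2-methylphenyl on a sulfonyl sulfur. Going by the values given here, the only measured step that bears on a change at the sulfonyl sulfur is the unreadable one from compound 1 to compound 2, so no size of step in this assay can be derived from the data for the change to compound 3. With both measured compounds sitting at the limit, the expectation for compound 3 is that it too stays at or beyond that limit, a step that the limit leaves unreadable from compound 2 to compound 3 being expected. Compound 3 is thus estimated at 15000 nM, within a range of 5000 nM to 50000 nM.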

Compound 3, half-maximal cytotoxic concentration: > 10000 nM
Compound 3: a limit, no number (the forecaster's own chance of this, stated with the estimate: 80%); the middle value lies beyond the limit too.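

In this assay compound 3 gives > 10000 nM as a limit and not as a number. The steps among compound 1, compound 2 and compound 3 therefore cannot be read, in size or in direction, and what stands is this: the limit of > 10000 nM in this assay, at which 3 of the 3 values shown sit.

The compounds shown leave open whether changing the group on the sulfonyl sulfur alters the result in this assay at all, and by how much.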